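A few compounds are considered here, and "the series" means these few. Any claim that something is new, unique, unknown or untested is made for them only; others in the source may bear on it.

Of the compounds shown here, three built on one shared core have been measured in a functional assay on MCF7 cells (Homo sapiens) for antiproliferative activity, read by CCK-8 assay, with a stated time of 48 h; on this read-out lower numbers stand for stronger inhibition and higher numbers for weaker inhibition. Compound 1 `C/C=C/C(=O)NCCOc1ccc(Oc2c(-c3ccc(F)cc3)sc3cc(O)ccc23)cc1` gives 21700 nM in this assay. Compound 3 `C/C=C/C(=O)N1CC(Oc2ccc(Oc3c(-c4ccc(F)cc4)sc4cc(O)ccc34)cc2)C1` gives 28000 nM in this assay. For compound 2 `C=C(C)C(=O)N1CC(Oc2ccc(Oc3c(-c4ccc(F)cc4)sc4cc(O)ccc34)cc2)C1` this assay reports only a limit, > 25000 nM. Of the two numbers shown, compound 1 stands lowest, and compound 3 is nearest: a 1.3-fold higher number from compound 1 to compound 3 (0.11 log units; within the scatter). Exchanging the chain for the ring gave an at least 1.1-fold higher number from compound 1 to compound 2 (0.06 log units; that floor lies within the scatter), a step read against a limit. The step that the limit leaves unreadable from compound 2 to compound 3 cannot be sized because of the limit of > 25000 nM in this assay, at which 1 of the 3 values shown sits.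

Compound 4 `C=CC(=O)NCCOc1ccc(Oc2c(-c3ccc(F)cc3)sc3cc(O)ccc23)cc1` is not yet measured. It differs from compound 1 in one place: vinyl in place of prop-1-en-1-yl on a carbonyl carbon. For the measured compounds named here, no measured step alters the group on the carbonyl carbon in a chain compound, and the one step that alters that group in the ring compounds is unreadable. Every readable step among the three measured compounds lies within the scatter, so nothing beyond the scatter is expected here either, in either direction. Compound 4 is therefore expected to give about 20000 nM in this assay, somewhere between 8000 nM and 50000 nM, which would be an expected step of a 1.1-fold lower number from compound 1 to compound 4 (0.04 log units; within the scatter).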

Compound 4, half-maximal inhibitory concentration: 23000 nM
Estimate against measurement, compound 4: 1.2-fold (0.06 log units) below; the range from low to high includes it.
By their numbers in this assay, from the lowest: compounds 1, 4 and 3 (each within the scatter of the next).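

In this assay, for the compounds shown here, exchanging prop-1-en-1-yl for vinyl on a carbonyl carbon whose other neighbour is an amide-type nitrogen gives a 1.1-fold higher number from compound 1 to compound 4 (0.03 log units; within the scatter), the first readable step for a change to this group, and it shows that this exchange makes no difference that can be told from the scatter. Setting the vinyl chain of compound 4 against a ring compound gives a 1.2-fold lower number from compound 3 to compound 4 (0.09 log units; within the scatter), so this pair, which differs in the whole group on the oxygen, cannot be told apart either. The comparison with the other ring compound gives an at least 1.0-fold lower number from compound 2 to compound 4 (0.03 log units; that floor lies within the scatter), and the steps involving compound 2 remain a floor or cannot be read at all because its value is a limit: the limit of > 25000 nM in this assay, at which 1 of the 4 values shown sits.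

The compounds shown leave open whether any group on this carbonyl carbon would move the number beyond the scatter, for example an ethyl group with no double bond, or a prop-1-en-1-yl group carrying a dimethylamino group. They also leave open whether a longer chain in place of the 2-carbon ethyl link would do so.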